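The source may report more compounds than this note shows. Statements on the series, on what has been measured and on what is new or still open speak of the compounds shown alone.

In a functional assay on CCRF-CEM cells (Homo sapiens) for cytotoxicity, read by MTT assay, with a stated time of 72 h (a higher number here means that more compound is tolerated, a lower number that less compound is tolerated), compound 2 `N#C[Se]c1ccc(NC(=O)OCc2ccccc2)cc1` gives 73700 nM. Compound 1 `N#C[Se]c1ccc(NC(=O)OCc2ccc([N+](=O)[O-])cc2)cc1` gives 68800 nM, and the step of a 1.1-fold higher number from compound 1 to compound 2 (0.03 log units; within the scatter) shows that the two lie within the scatter of each other. Compound 3 `N#C[Se]c1ccc(NC(=O)OCC2=Cc3ccccc3S2(=O)=O)cc1` gives 8900 nM, well below compound 2 and beyond the scatter. Compound 4 `CCCCCCOC(=O)Nc1ccc([Se]C#N)cc1` differs from compound 2 by pentyl in place of phenyl on a saturated chain carbon bound to an oxygen next to a carbonyl group. For the measured compounds named here, no measured pair covers a change at this place; the only single-point step, from compound 1 to compound 2, concerns a different position and stays within the scatter, so nothing measured predicts a shift here. The step of a 1.1-fold lower number from compound 2 to compound 4 (0.05 log units; within the scatter) is therefore expected to remain within the scatter. Compound 4 is estimated at 65000 nM, with a range from 22000 nM to 190000 nM.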

Compound 4, concentration lethal to 50% of the cells: 72700 nM
Compound 4: the middle estimate sits 1.1-fold (0.05 log units) below what was measured; the measured number falls inside the stated range.
By their numbers in this assay, from the lowest: compound 3; then compounds 1, 4 and 2 (each within the scatter of the next).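

In this assay, for the compounds shown here, the step of a 1.0-fold lower number from compound 2 to compound 4 (0.01 log units; within the scatter) is the first measured change on a saturated chain carbon bound to an oxygen next to a carbonyl group. With pentyl in place of phenyl, the six-membered aromatic ring is gone and the number stays within the scatter, so this pair does not depend on that ring. No measurement at hand explains this result. Going by these compounds, whether a longer chain, an amine or a carboxylic acid at this place would hold the number or shift it beyond the scatter remains open.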